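The source may hold more compounds than are shown below. What is called first, only, known or untested is meant among the compounds shown, and "the series" means these compounds.

Compounds measured in a functional assay on MOLT-4 cells (Homo sapiens) for inhibition, read by sulforhodamine B assay, with a stated time of 48 h; on this read-out higher numbers stand for weaker inhibition of growth and lower numbers for stronger inhibition of growth:
compound 1 `Nc1cc(N)c2nc(-c3ccccc3)c(Oc3ccc(Cl)c(Cl)c3)nc2c1` gives < 100000 nM.
compound 2 `Nc1cc(N)c2nc(-c3ccccc3)c(NCc3ccc(Cl)c(Cl)c3)nc2c1` gives < 100000 nM.
compound 3 `Nc1cc(N)c2nc(-c3ccccc3)c(Sc3ccc(F)cc3)nc2c1` gives < 100000 nM.

Compound 1 has as its figure a limit of this assay, not a number. Compound 2 has as its figure likewise a limit. Compound 3 has as its figure likewise a limit. Compound 1 therefore has no fixed standing among the values shown: as the limit of < 100000 nM in this assay, at which 3 of the 3 values shown sit, records, every value in the set sits at one and the same limit, and no ordering of the three compounds can be read from them.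

The step under consideration leads to compound 4 `Nc1cc(N)c2nc(-c3ccccc3)c(Oc3ccc(F)cc3)nc2c1`, not yet measured: 4-fluorophenyl in place of 3,4-dichlorophenyl on an oxygen on an aromatic ring. Going by the values given here, the only measured step that touches this change is a step that the two limits leave unreadable from compound 1 to compound 3, which alters the same outer ring together with the linking atom; it runs between two limits and its size is not readable. Compound 2 lies off this path and adds no scale of its own.

No size or direction of step in this assay can be drawn from these data; the expected step is a step that the limit leaves unreadable from compound 1 to compound 4, that is, nothing beyond the scatter. Compound 4 is estimated at 30000 nM, with an expected range from 3000 nM to 100000 nM, and the reading is expected most likely to be another limit.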

Compound 4, concentration for total growth inhibition: < 100000 nM
Compound 4: a limit, no number; the forecaster's own chance of this, stated with the estimate: 70%; the middle value does not contradict the limit.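

In this assay no new step can be read between compound 4 and either compound 1 or compound 3, because all of these values are limits rather than numbers: the limit of < 100000 nM in this assay, at which 4 of the 4 values shown sit.

The compounds shown leave open how far each one lies from that limit, and whether 3,4-dichlorophenoxy, 4-fluorophenoxy and (4-fluorophenyl)sulfanyl differ at all in this read-out.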